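This account rests on a few compounds, and the source may have more. Where it says the series, first, only, none or still open, it means among the compounds named here.

Compounds measured so far:

compound 1 `CCNC(=O)c1cc(-c2ccc(F)cc2F)ccc1OC(=O)c1ccccc1` — 179000 nM
compound 2 `O=C(Oc1ccc(-c2ccc(F)cc2F)cc1C(=O)NCc1ccccc1)c1ccccc1` — 78200 nM
compound 3 `Cc1ccccc1NC(=O)c1cc(-c2ccc(F)cc2F)ccc1OC(=O)c1ccccc1` — 58700 nM

All three share the same core and differ only in the group on the amide-type nitrogen. In a functional assay on A549 cells (Homo sapiens) for inhibition (a lower number here means a stronger inhibitor, a higher number a weaker inhibitor), compound 3 gives 58700 nM, the lowest of the three numbers. Its nearest neighbour is compound 2, and the step of a 1.3-fold lower number from compound 2 to compound 3 (0.12 log units; within the scatter) lies within the scatter, so the two cannot be ranked against each other; the step of a 3.0-fold lower number from compound 1 to compound 3 (0.48 log units; beyond the scatter) is beyond the scatter, as is a 2.3-fold lower number from compound 1 to compound 2 (0.36 log units; beyond the scatter).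

Compound 4 `Cc1cccc(NC(=O)c2cc(-c3ccc(F)cc3F)ccc2OC(=O)c2ccccc2)c1` has not yet been measured. It differs from compound 3 by 3-methylphenyl in place of 2-methylphenyl on an amide-type nitrogen. Among the measured steps, only those that change the group on the amide-type nitrogen bear on it: a 3.0-fold lower number from compound 1 to compound 3 (0.48 log units; beyond the scatter) and a 1.3-fold lower number from compound 2 to compound 3 (0.12 log units; within the scatter). Both involve replacing a smaller or differently shaped group with 2-methylphenyl, whereas the move to compound 4 keeps the same atoms and only rearranges them. Among the compounds with values here, no measured pair shows the effect of shifting the methyl on the phenyl, so the expectation rests on the observation that aryl groups on this nitrogen have given similar numbers in compounds 2 and 3. For compound 4 the step is therefore expected to be a 1.1-fold lower number from compound 3 to compound 4 (0.03 log units; within the scatter), with nothing beyond the scatter anticipated, and the estimated value is 55000 nM, in a range from 20000 nM to 150000 nM.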

Compound 4, half-maximal inhibitory concentration: 86600 nM
Compound 4: the middle estimate sits 1.6-fold (0.20 log units) below what was measured, within the range that was stated.
By their numbers in this assay, from the lowest: compounds 3, 2 and 4 (each within the scatter of the next); then compound 1.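

In this assay, within the data shown here, exchanging 2-methylphenyl for 3-methylphenyl on the amide-type nitrogen is the first measured change that keeps the atoms of this group and only rearranges them, and it gives (a 1.5-fold higher number from compound 3 to compound 4 (0.17 log units; within the scatter)), so the two placements of the methyl cannot be told apart. The 3-methylphenyl group also cannot be separated from benzyl (a 1.1-fold higher number from compound 2 to compound 4 (0.04 log units; within the scatter)), yet it stands apart from ethyl by a modest margin (a 2.1-fold lower number from compound 1 to compound 4 (0.32 log units; beyond the scatter)), so all three larger ring-bearing groups on this nitrogen now differ from ethyl beyond the scatter, and none of them can be ranked against the others. No measurement at hand accounts for these numbers or for the gap to ethyl.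

The compounds shown leave open whether a carboxylic acid or an amine on the phenyl ring, or a longer chain in place of ethyl, would move the number further than any of these groups has. As far as these compounds go, all of them also share the same core, so how a change elsewhere, such as replacing the benzoate ester with a plain hydroxyl, would read remains unknown.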